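Aryl Swap on the Triazole Nitrogen in a Cytotoxicity Series

The source may hold more compounds than are shown below. What is called first, only, known or untested is meant among the compounds shown, and "the series" means these compounds.

compound 1 `COc1ccccc1-n1cc(COc2c(/C=C\C(=O)O)ccc(OC)c2CC=C(C)C)nn1`: 32600 nM in a functional assay on A-431 cells (Homo sapiens) for cytotoxicity, read by MTT assay, with a stated time of 24 h; on this read-out lower numbers stand for stronger inhibition and higher numbers for weaker inhibition
compound 2 `COc1ccc(/C=C\C(=O)O)c(OCc2cn(-c3ccccc3F)nn2)c1CC=C(C)C`: 12400 nM
compound 3 `COc1ccc(/C=C\C(=O)O)c(OCc2cn(-c3ccc(CO)cc3)nn2)c1CC=C(C)C`: 16400 nM

Among these three numbers compound 3 holds the second highest value; compound 2 is its nearest neighbour and compound 1 its furthest, and both gaps lie within the scatter. Compound 4 `COc1ccc(/C=C\C(=O)O)c(OCc2cn(-c3cccc([N+](=O)[O-])c3)nn2)c1CC=C(C)C` differs from compound 3 by 3-nitrophenyl in place of 4-(hydroxymethyl)phenyl on an aromatic nitrogen. Two earlier swaps at the same aromatic nitrogen bear on this step: a 2.0-fold lower number from compound 1 to compound 3 (0.30 log units; within the scatter) and a 1.3-fold higher number from compound 2 to compound 3 (0.12 log units; within the scatter), both within the scatter. For the measured compounds named here, the only step beyond the scatter, a 2.6-fold lower number from compound 1 to compound 2 (0.42 log units; beyond the scatter), concerns a different place. Hence no step beyond the scatter is expected in this assay; the expected step is a 1.2-fold lower number from compound 3 to compound 4 (0.07 log units; within the scatter). Compound 4 is estimated at 14000 nM, with a range from 6000 nM to 35000 nM.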

Compound 4, half-maximal inhibitory concentration: 18400 nM
Estimate against measurement, compound 4: 1.3-fold (0.12 log units) below; low and high end bracket the measured number.
By their numbers in this assay, from the lowest: compounds 2, 3, 4 and 1 (each within the scatter of the next, the first and the last beyond it).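

With 3-nitrophenyl on the aromatic nitrogen, this assay gives a 1.1-fold higher number from compound 3 to compound 4 (0.05 log units; within the scatter) and then a 1.5-fold higher number from compound 2 to compound 4 (0.17 log units; within the scatter) and also a 1.8-fold lower number from compound 1 to compound 4 (0.25 log units; within the scatter) so compound 4 lies within the scatter of every earlier compound. Replacing 4-(hydroxymethyl)phenyl, which has a hydrogen-bond donor, with 3-nitrophenyl, which has none, therefore brings no readable change at this nitrogen. On these data alone, whether a longer alkyl chain on this nitrogen, or an amine on its aryl ring, would move the number beyond the scatter stays open. Nothing available explains why these aryl swaps give such similar numbers.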